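A few compounds are considered here, and "the series" means these few. Any claim that something is new, unique, unknown or untested is made for them only; others in the source may bear on it.

Compound 1, `O=C(CN(c1ncnc2c1ncn2C1CCCCO1)C1CC1)N[C@@H](CCC(=O)OCc1ccccc1)C(=O)OCc1ccccc1`, opens this account. In a functional assay on the whole organism (Tail, strain ICR) with Mus musculus as the target, in the tail flick test, with a stated time of 30 min, at a dose of 25 umol/kg by the oral route (a higher number here means a stronger effect of the compound at the dose given, a lower number a weaker effect), compound 1 gives 32.6%. Two further compounds were run in the same test: compound 2, `NC(=O)C[C@H](NC(=O)CN(c1nc(Cl)nc2[nH]cnc12)C1CC1)C(=O)O`, gives 29.7% in this assay, and compound 3, `NCCCC[C@H](NC(=O)CN(c1nc(Cl)nc2[nH]cnc12)C1CC1)C(=O)OCc1ccccc1`, gives 26.1%. The number for compound 1 is the highest of the three, yet compound 2, the nearest, lies within the usual scatter of it, and compound 3, the furthest, also lies within that scatter; the three readings therefore cannot be separated, and no one of them can be called the stronger.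

Compound 4, `NC(=O)C[C@H](NC(=O)CN(c1ncnc2c1ncn2C1CCCCO1)C1CC1)C(=O)OCc1ccccc1`, has not yet been measured. It differs from compound 1 in a single place: carbamoyl in place of (benzyloxycarbonyl)methyl on a saturated chain carbon, two bonds along the chain from an amide-type nitrogen and a carbonyl carbon. Within the data shown here, no two measured compounds differ from each other by just this change, so no measured step exists to guide the expectation. Compounds 2 and 3 differ from compound 1 in several places at once and still return numbers close to it, which points toward little movement. The step is expected to stay within the scatter, with no clear direction, and is estimated as a number 2.6 percentage points lower from compound 1 to compound 4 (within the scatter). Compound 4 is accordingly expected to give about 30% in this assay, somewhere between 18% and 42%.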

Compound 4, a percentage reported as activity, at one dose (the size of the read-out at that dose, not a potency): 34.5%
The estimate for compound 4 lay 4.5 percentage points below the measured number, and the stated range covers the measured number.
By their numbers in this assay, from the lowest: compounds 3, 2, 1 and 4 (each within the scatter of the next).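

Among these compounds, the step at this place, on a saturated chain carbon, two bonds along the chain from an amide-type nitrogen and a carbonyl carbon, is the first that isolates a single change: carbamoyl in place of (benzyloxycarbonyl)methyl gives, in this assay, a number 1.9 percentage points higher from compound 1 to compound 4 (within the scatter) and so leaves the two compounds inseparable. The earlier compounds shown here could not show this, since compounds 2 and 3 differ from compound 1 in several places at once, whereas here the loss of the six-membered aromatic ring of carbon only, with the group going from 11 heavy atoms to 3, is the sole difference and is not seen in the read-out at this dose. Nothing in the available data offers an explanation for this outcome.

On these data alone, it remains open whether a methyl group, a primary amine or a longer chain ending in a carboxylic acid at this same place would also stay within the scatter of compound 1. Also open, as far as these compounds go, is whether this single change would remain as silent at other doses or at other times after dosing.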